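The compounds below may be only part of what the source reports. "The series", "measured", "known", "first", "only" and "open" are said of these compounds alone.

Compound 2 `CC(C)c1ccc(NC(=O)N[C@H](C)c2ccccc2)cc1` gives 49% in an ADME assay on the whole organism with Oryza sativa as the target, tested at 10 uM (on this read-out higher numbers stand for a weaker effect at the one concentration tested and lower numbers for a stronger effect), and stands lowest of the three numbers measured. Compound 3 `CC(C)c1ccc(NC(=O)N[C@@H](C)c2ccccc2)cc1` gives 86% and compound 1 `CC(C)c1ccccc1NC(=O)N[C@@H](C)c1ccccc1` gives 93% in this assay. Among the measured compounds shown here, the one step between compounds that differ in a single place is a number 37 percentage points higher from compound 2 to compound 3 (beyond the scatter), and it rests on (the fact that compounds 2 and 3 differ only in the configuration as drawn); it involves no exchange of a group. Compound 4 `C[C@@H](NC(=O)Nc1ccc(C(F)(F)F)cc1)c1ccccc1` is the next member to be measured. From compound 2 the change is trifluoromethyl in place of isopropyl on an aromatic carbon. For the measured compounds named here, no measured step exchanges one group on the aromatic ring for another, so none of them fixes the size or direction of this change; the only step available, from compound 2 to compound 3, changes the configuration as drawn and leaves the groups on the rings untouched. With nothing shown to move the number either way, the expectation for compound 4 in this assay is a step of a number 6 percentage points higher from compound 2 to compound 4 (within the scatter), with a wide range around it. Compound 4 is estimated at 55%, between 25% and 85%.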

Compound 4, a percentage reported as activity, at one concentration (the size of the read-out at that concentration, not a potency): 82%
For compound 4 the middle estimate is 27 percentage points below the measured one; low and high end bracket the measured number.
By their numbers in this assay, from the lowest: compound 2; then compounds 4, 3 and 1 (each within the scatter of the next, the first and the last beyond it).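

In this assay, the exchange of one group for another on the aromatic ring now has a measured size: trifluoromethyl in place of isopropyl, para to a large group, gives a number 33 percentage points higher from compound 2 to compound 4 (beyond the scatter), so the number at this position depends on the group it carries. This step runs in the same direction as a number 37 percentage points higher from compound 2 to compound 3 (beyond the scatter), toward a weaker effect on this read-out, so a single change at either place is enough to move the number upward from compound 2. No measured property on hand accounts for the exchange of isopropyl for trifluoromethyl.

The compounds shown leave open whether this exchange has a similar size with the stereocentre in the opposite configuration. They also leave open where other groups at this position, such as methoxy, chlorine or a carboxylic acid, would fall relative to compound 2.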